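Bromo in Place of Methyl, Made Twice

A few compounds are considered here, and "the series" means these few. Any claim that something is new, unique, unknown or untested is made for them only; others in the source may bear on it.

Compound 1 `Cc1ccc(NC(=S)Nn2c(S)nnc2-c2ccncc2)cc1` and compound 2 `S=C(Nc1ccc(Br)cc1)Nn1c(S)nnc1-c1ccncc1` share one core. In a functional assay on HA22T cells (Homo sapiens) for cytotoxicity, read by sulforhodamine B assay, with a stated time of 24 h (on this read-out higher numbers stand for weaker inhibition and lower numbers for stronger inhibition), compound 1 gives 2380 nM, and compound 2 gives 3200 nM. The change between them is bromo in place of methyl on an aromatic carbon, and it made a 1.3-fold higher number from compound 1 to compound 2 (0.13 log units; within the scatter).

Compound 3 `Cc1ccc(Nc2nn3c(-c4ccncc4)nnc3s2)cc1` is built on another core; the difference between the two cores is not broken down here. In this assay compound 3 gives 277 nM, the lowest of the three numbers and beyond the scatter from both compound 1 and compound 2.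

Compound 4 `Brc1ccc(Nc2nn3c(-c4ccncc4)nnc3s2)cc1` carries the same change on the core of compound 3: bromo in place of methyl on an aromatic carbon. Compound 4 is expected to stay close to compound 3, with a step of a 1.3-fold higher number from compound 3 to compound 4 (0.11 log units; within the scatter), because the earlier step of a 1.3-fold higher number from compound 1 to compound 2 (0.13 log units; within the scatter) stayed within the scatter. Compound 4 is estimated at 360 nM, between 170 nM and 760 nM.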

Compound 4, half-maximal inhibitory concentration: 782 nM
Beside the measured number, compound 4's estimate is 2.2-fold (0.34 log units) below it; measured number outside the range, above it.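

On the second core, bromo in place of methyl made a 2.8-fold higher number from compound 3 to compound 4 (0.45 log units; beyond the scatter), a modest step that lies beyond the usual scatter, whereas the same change on the first core did not. Even so, the two steps cannot be told apart once the scatter of both is counted: the same change on two cores in this assay, a 1.3-fold higher number (0.13 log units; within the scatter) from compound 1 to compound 2 and a 2.8-fold higher number (0.45 log units; beyond the scatter) from compound 3 to compound 4, 2.1-fold (0.32 log units) apart, within the scatter of two such steps. For the compounds shown here, this fits a change that carries from one core to the other at a similar size, but two pairs in this assay cannot establish that rule, and they do not explain why only one step clears the scatter.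

The compounds shown leave open how other groups in this place, such as chloro, methoxy or an amine, would behave on these two cores. From the compounds shown here alone, whether either step would hold in another assay also remains open.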